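The source may hold more compounds than are shown below. What is called first, only, known or untested is meant among the compounds shown, and "the series" means these compounds.

Measured so far:

- compound 1, `COc1cc2c(Oc3ccc(NC(=O)c4nn(-c5ccccc5OC(F)(F)F)c(=O)cc4C)cc3F)ccnc2cc1OCCCN1CCC(C)CC1`: 90 nM in a functional assay on A549 cells (Homo sapiens) for inhibition, read by MTT assay, with a stated time of 72 h; a lower number here means a stronger inhibitor, a higher number a weaker inhibitor
- compound 2, `COc1cc2c(Oc3ccc(NC(=O)c4nn(-c5cccc(F)c5)c(=O)cc4C)cc3F)ccnc2cc1OCCCN1CCCCC1`: 250 nM in this assay

Both compounds share one core and differ in two places at once: the ring attached to the pyridazinone nitrogen and the saturated amine ring at the end of the three-carbon chain. Going by the values given here, with only two numbers in hand, compound 2 stands at the higher of them, and compound 1 lies well away from it, beyond what repeated measurements usually scatter. Because the two compounds differ in more than one place, the gap between them cannot be assigned to either change alone.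

Compound 3, `COc1cc2c(Oc3ccc(NC(=O)c4nn(-c5cccc(F)c5)c(=O)cc4C)cc3F)ccnc2cc1OCCCN1CCC(C)CC1`, is not yet measured. Its difference from compound 2 is a single one: methyl in place of hydrogen on a saturated ring carbon. A change of this size, a single carbon added to a saturated ring far from the amide, is the kind that often leaves the number close to where it was. The step from compound 2 to compound 3 in this assay is therefore expected to be small, a 1.3-fold lower number from compound 2 to compound 3 (0.10 log units; within the scatter), and likely within the usual scatter. For compound 3 the estimated value in this assay is 200 nM, with a range from 80 nM to 500 nM.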

Compound 3, half-maximal inhibitory concentration: 250 nM
Compound 3: the middle estimate sits 1.3-fold (0.10 log units) below what was measured, and the stated range covers the measured number.
By their numbers in this assay, from the lowest: compound 1; then compounds 2 and 3 (each within the scatter of the next).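

In this assay, the change from piperidin-1-yl to 4-methylpiperidin-1-yl gives no change at the digits printed from compound 2 to compound 3 (within the scatter), so with 3-fluorophenyl on the aromatic nitrogen, this saturated ring carbon carries a methyl with no readable shift in the number. Compound 3 also supplies the first comparison with compound 1 that differs in one place: with the 4-methylpiperidin-1-yl group held constant, 3-fluorophenyl in place of 2-(trifluoromethoxy)phenyl gives a 2.8-fold higher number from compound 1 to compound 3 (0.44 log units; beyond the scatter), making the group on the aromatic nitrogen the one change shown here that moves the number beyond the scatter. No measurement available here speaks to the reason for either result.

From the compounds shown here alone, it remains open whether the methyl step would read the same with 2-(trifluoromethoxy)phenyl on the aromatic nitrogen, and whether an ethyl or a hydroxyl group on the same ring carbon would also leave the number in place. Going by these compounds, it is also open whether the step on the aromatic nitrogen comes from the 2-(trifluoromethoxy) group itself, a question that a compound with plain phenyl or 2-methoxyphenyl there could help to answer.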